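The source may report more compounds than this note shows. Statements on the series, on what has been measured and on what is new or still open speak of the compounds shown alone.

Among the compounds with values here, in an assay on HepG2 cells for agonist activity at nuclear receptor subfamily 1 group I member 3 (Homo sapiens), read by a luciferase reporter, with a stated time of 23 h (on this read-out lower numbers stand for an effect already at smaller amounts and higher numbers for an effect only at larger amounts of compound), compound 2 `FC(F)(F)c1ccc(-c2nc3sccn3c2/C=N/OCc2ccc(Cl)c(Cl)c2)cc1` gives 880 nM, and the only other compound so far, compound 1 `Clc1cccc(-c2nc3sccn3c2/C=N/OCc2ccc(Cl)c(Cl)c2)c1`, gives 1100 nM; the step of a 1.3-fold lower number from compound 1 to compound 2 (0.10 log units; within the scatter) leaves the two within the scatter of each other. Compound 3 `Clc1ccc(CO/N=C/c2c(-c3ccc4ccccc4c3)nc3sccn23)cc1Cl` differs from compound 2 by naphthalen-2-yl in place of 4-(trifluoromethyl)phenyl on an aromatic carbon. Within the data shown here, the sole step that bears on this sits on the same aromatic carbon, yet it swaps a different pair of groups and stayed within the scatter, so it offers little guidance in either direction. The expected step is therefore a 1.0-fold higher number from compound 2 to compound 3 (0.01 log units; within the scatter). Compound 3 is expected to give 900 nM, with a range from 400 nM to 2200 nM.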

Compound 3, half-maximal effective concentration: 380 nM
Compound 3: the middle estimate sits 2.4-fold (0.37 log units) above what was measured, outside the stated range (below it).
By their numbers in this assay, from the lowest: compound 3; then compounds 2 and 1 (each within the scatter of the next).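

In this assay, the group on this aromatic carbon now makes a difference beyond the scatter: naphthalen-2-yl, with 2 six-membered aromatic rings of carbon only, gives a 2.3-fold lower number from compound 2 to compound 3 (0.36 log units; beyond the scatter) and also a 2.9-fold lower number from compound 1 to compound 3 (0.46 log units; beyond the scatter). Both steps are modest, whereas the earlier swap between the two substituted phenyl groups stayed within the scatter. No measurement here explains the gain. Still open is whether both rings of naphthalen-2-yl are needed, since the compounds shown stop at this one group. From the compounds shown here alone, how a quinoline ring, or a phenyl ring carrying an amine or a carboxylic acid, would behave on this carbon also remains unknown.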